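Chain extension at the stereocentre series: compound 2 to compound 4

The compounds below may be only part of what the source reports. "The series", "measured", "known", "first", "only" and "open" are said of these compounds alone.

Values in a functional assay on HCT-116 cells (Homo sapiens) for antiproliferative activity, read by MTT assay, with a stated time of 48 h; on this read-out higher numbers stand for weaker inhibition and lower numbers for stronger inhibition:
- compound 1 `CCCCCCC[C@H](CCO)n1cnc2c(Cl)ncnc21`: 2670 nM
- compound 2 `CCCCCCCC[C@H](CCO)n1cnc2c(Cl)ncnc21`: 1120 nM
- compound 3 `CCCCCCCCC(CCO)n1cnc2c(Cl)ncnc21`: 1650 nM

Compound 2 gives 1120 nM and stands clear of only one of the other two measured compounds. That gap is a 2.4-fold lower number from compound 1 to compound 2 (0.38 log units; beyond the scatter), for methyl in place of hydrogen on a saturated chain carbon, eight bonds along the chain from an aromatic nitrogen. The other comparison rests on the fact that one of compounds 2 and 3 is drawn with a defined configuration and the other without, at the place where they differ and amounts to a 1.5-fold higher number from compound 2 to compound 3 (0.17 log units; within the scatter), so it sets the two level and says nothing about chain length.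

Compound 4 `CCCCCCCCC[C@H](CCO)n1cnc2c(Cl)ncnc21` keeps the configuration drawn in compound 2 and differs from it as follows: methyl in place of hydrogen on a saturated chain carbon, nine bonds along the chain from an aromatic nitrogen. Among the compounds with values here, the same kind of change was made once before, so the single step of a 2.4-fold lower number from compound 1 to compound 2 (0.38 log units; beyond the scatter) is the only guide in this assay. One step cannot show whether the trend carries on or levels off, so a somewhat smaller move in the same downward direction is the cautious expectation. The expected step is a 1.5-fold lower number from compound 2 to compound 4 (0.17 log units; within the scatter). Compound 4 is estimated at 750 nM, with an expected range of 350 nM to 1700 nM.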

Compound 4, half-maximal inhibitory concentration: 450 nM
Estimate against measurement, compound 4: 1.7-fold (0.22 log units) above; measured number inside the range.
By their numbers in this assay, from the lowest: compound 4; then compounds 2, 3 and 1 (each within the scatter of the next, the first and the last beyond it).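

In this assay, a second methyl in place of hydrogen on the saturated chain gives a 2.5-fold lower number from compound 2 to compound 4 (0.40 log units; beyond the scatter), a move in the same direction as a 2.4-fold lower number from compound 1 to compound 2 (0.38 log units; beyond the scatter) and with no sign of levelling off at this point. Taken together, the two changes amount to ethyl in place of hydrogen, eight bonds along the chain from an aromatic nitrogen, and give a 5.9-fold lower number from compound 1 to compound 4 (0.77 log units; beyond the scatter), so the series now has a run of three compounds with the same drawn configuration, and none of compounds 1, 2 and 4 goes against the fall in the number as the chain grows. Nothing available bears on what lies behind this dependence on chain length.

Going by these compounds, whether a still longer chain continues the fall, holds it or reverses it remains open, as does whether the trend depends on the chain staying purely hydrocarbon, which a phenyl, an amine or a carboxylic acid at the same place would test. The compounds shown also leave open how the opposite configuration at the stereocentre would behave along this series, and whether the trend extends beyond this one cell line.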